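Repeating a Chlorophenyl-for-Naphthyl Swap on a Second Core

The source may report more compounds than this note shows. Statements on the series, on what has been measured and on what is new or still open speak of the compounds shown alone.

Compound 1 `COc1ccc(/C=C/c2cc(OC)c(OC)c(OC)c2-c2ccc3ccccc3c2)cc1` and compound 3 `C=C(c1ccc(OC)cc1)c1cc(OC)c(OC)c(OC)c1-c1ccc2ccccc2c1` are built from the same atoms joined differently: 1-(4-methoxyphenyl)ethenyl in place of 2-(4-methoxyphenyl)ethenyl on an aromatic carbon. In a functional assay on DU-145 cells (Homo sapiens) for cytotoxicity, read by MTT assay, with a stated time of 48 h (a higher number here means a weaker inhibitor, a lower number a stronger inhibitor), compound 1 gives 32000 nM, and compound 3 gives 46000 nM; the step between them is a 1.4-fold higher number from compound 1 to compound 3 (0.16 log units; within the scatter). Compound 2 `COc1ccc(/C=C/c2cc(OC)c(OC)c(OC)c2-c2ccc(Cl)cc2)cc1` differs from compound 1 in a single place: 4-chlorophenyl in place of naphthalen-2-yl on an aromatic carbon. In this assay compound 2 gives 35000 nM, so the step is a 1.1-fold higher number from compound 1 to compound 2 (0.04 log units; within the scatter). All three measured numbers lie within the scatter of one another, and none of the three can be called the most or least potent.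

Compound 4 `C=C(c1ccc(OC)cc1)c1cc(OC)c(OC)c(OC)c1-c1ccc(Cl)cc1` has not yet been measured. It differs from compound 3 by the same kind of change: 4-chlorophenyl in place of naphthalen-2-yl on an aromatic carbon. The surroundings of the place are not identical in the two cases: in compound 3 the place is ortho to a 1-(4-methoxyphenyl)ethenyl group, whereas in compound 1 it is ortho to a 2-(4-methoxyphenyl)ethenyl group; the methoxy groups ortho, meta and para to the place are the same in both.

Because the earlier occurrence of this change gave a 1.1-fold higher number from compound 1 to compound 2 (0.04 log units; within the scatter), the expected step in this assay is a 1.1-fold higher number from compound 3 to compound 4 (0.04 log units; within the scatter), a change that would stay within the scatter. This expectation rests on a single precedent, so the range is kept wide. Compound 4 is therefore estimated at 50000 nM in this assay, with a likely span from 25000 nM to 100000 nM.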

Compound 4, half-maximal inhibitory concentration: 33000 nM
Beside the measured number, compound 4's estimate is 1.5-fold (0.18 log units) above it, within the range that was stated.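

In this assay, putting 4-chlorophenyl in place of naphthalen-2-yl on the core of compound 3 gives a 1.4-fold lower number from compound 3 to compound 4 (0.14 log units; within the scatter). Set beside the earlier occurrence of the same change, this step does not differ from it: the same change on two cores in this assay, a 1.1-fold higher number (0.04 log units; within the scatter) from compound 1 to compound 2 and a 1.4-fold lower number (0.14 log units; within the scatter) from compound 3 to compound 4, 1.5-fold (0.18 log units) apart, within the scatter of two such steps. Among these compounds, this shows that on both cores the swap of two aromatic rings for one leaves a step too small to read, so the change carries over in the sense that neither the 2-(4-methoxyphenyl)ethenyl nor the 1-(4-methoxyphenyl)ethenyl compounds separate the two groups, but it does not show that the change has a shared size or direction, and the opposite signs of the two steps carry no meaning, with only two cores and one cell assay behind them.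

From the compounds shown here alone, all four compounds carry either naphthalen-2-yl or 4-chlorophenyl at this place, together with the same methoxy groups, so it remains open how a phenyl ring bearing an amine or a carboxylic acid would read in this assay. Going by these compounds, it also remains open whether the swap would stay this small on a core whose numbers stand well away from these.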